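The compounds below may be only part of what the source reports. "The series", "measured", "known", "first", "only" and "open" are said of these compounds alone.

Compound 3 `CC(C)C[C@@H](NC(=S)Nc1cc(C(F)(F)F)cc(C(F)(F)F)c1)c1nc2ccccc2[nH]1` gives 10400 nM in a functional assay on HeLa cells (Homo sapiens) for cytotoxicity, read by MTT assay (a higher number here means a weaker inhibitor, a lower number a stronger inhibitor), the lowest of the three numbers recorded so far. Compound 1 `CC(C)[C@H](NC(=S)Nc1cc(C(F)(F)F)cc(C(F)(F)F)c1)c1nc2ccccc2[nH]1` gives 28900 nM in this assay, and compound 2 `C[C@H](NC(=S)Nc1cc(C(F)(F)F)cc(C(F)(F)F)c1)c1nc2ccccc2[nH]1` gives 133000 nM. The one single-point step among these, a 4.6-fold higher number from compound 1 to compound 2 (0.66 log units; beyond the scatter), concerns the size of the group on the chain carbon, not its configuration. Compound 4 `CC(C)C[C@H](NC(=S)Nc1cc(C(F)(F)F)cc(C(F)(F)F)c1)c1nc2ccccc2[nH]1` is the mirror image of compound 3: the two compounds have the same atoms and bonds and differ only in configuration as drawn: 1 of 1 stereo elements differ; a stereocentre at a saturated chain carbon is drawn R in compound 3 and S in compound 4. For the measured compounds named here, no measured pair in this set shares its atoms and bonds and differs only in configuration, so none of the recorded steps bears directly on the change from compound 3 to compound 4; the data give no guide to its direction. The step is therefore estimated as a 1.4-fold higher number from compound 3 to compound 4 (0.16 log units; within the scatter), essentially no change beyond the scatter, with a deliberately wide range around it. Compound 4 is expected to give 15000 nM in this assay, somewhere between 4000 nM and 60000 nM.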

Compound 4, half-maximal inhibitory concentration: 18100 nM
Compound 4: middle estimate off by 1.2-fold (0.08 log units), on the low side; low and high end bracket the measured number.
By their numbers in this assay, from the lowest: compounds 3, 4 and 1 (each within the scatter of the next, the first and the last beyond it); then compound 2.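

This is the first pair in this assay that isolates the stereocentre at the saturated chain carbon, and the step, a 1.7-fold higher number from compound 3 to compound 4 (0.24 log units; within the scatter), shows that inverting it leaves the number within the scatter, a reading that is clean on one point: the fact that compounds 3 and 4 differ only in the configuration as drawn

With the chain group changed instead, isobutyl in place of isopropyl gives a 1.6-fold lower number from compound 1 to compound 4 (0.20 log units; within the scatter), so these two groups do not separate either. For the compounds shown here, only the step to the smaller group stands out, a 7.3-fold lower number from compound 2 to compound 4 (0.87 log units; beyond the scatter), which places the methyl compound apart from the others at this position.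

As far as these compounds go, whether a benzyl or a hydroxymethyl group on this chain carbon would keep the number or move it remains open. So does whether configuration counts as little when the group there is methyl or isopropyl.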